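Swapping a Propyl Ketone for a Diethylamide

The source may hold more compounds than are shown below. What is called first, only, known or untested is meant among the compounds shown, and "the series" means these compounds.

Compound 1 `CCCC(=O)C1=C(C)NC(=O)NC1c1ccco1` and compound 2 `CCCC(=O)C1=C(C)NC(=O)NC1c1ccsc1` are the two measured compounds. Going by the values given here, in an assay on membranes from CHO cells for displacement of a labelled ligand from adenosine receptor A1 (Homo sapiens), read by scintillation counting, with a stated time of 60 min, tested at 1 uM (on this read-out higher numbers stand for more inhibition at the one concentration tested (going by the name of the read-out) and lower numbers for less inhibition), compound 1 gives 1%, and compound 2 gives 6%, so the two numbers do not differ beyond the scatter, as the one measured step, a number 5 percentage points higher from compound 1 to compound 2 (within the scatter), shows. That step changes the ring on a saturated ring carbon, not the carbonyl. Compound 3 `CCN(CC)C(=O)C1=C(C)NC(=O)NC1c1ccco1` differs from compound 1 by diethylamino in place of propyl on a carbonyl carbon. Among the compounds with values here, no measured step touches the carbonyl carbon, so nothing here points to a change beyond the scatter. Compound 3 is therefore expected to give 3%, between -8% and 15%. That estimate means an expected step of a number 2 percentage points higher from compound 1 to compound 3 (within the scatter).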

Compound 3, a percentage reported as inhibition, at one concentration (the size of the read-out at that concentration, not a potency): 11%
Compound 3: middle estimate off by 8 percentage points, on the low side; the range from low to high includes it.
By their numbers in this assay, from the lowest: compounds 1, 2 and 3 (each within the scatter of the next).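

Diethylamino in place of propyl on a carbonyl carbon gives a number 10 percentage points higher from compound 1 to compound 3 (within the scatter) in this assay, the first measured step at this position. At this one concentration, the read-out therefore does not separate the propyl ketone from the diethylamide, even though the entering group brings a nitrogen. No measured evidence bears on this result.

On these data alone, whether piperidine, dimethylamino or a longer chain on the carbonyl carbon would move the number beyond the scatter stays open. So does the effect of diethylamino with thiophen-3-yl in place of furan-2-yl on the saturated ring carbon.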